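The compounds below may be only part of what the source reports. "The series", "measured", "known", "first", "only" and "open" are said of these compounds alone.

Three compounds with measured values share one core and differ in the group on an aromatic nitrogen. In a functional assay on MDA-MB-231 cells (Homo sapiens) for antiproliferative activity, read by MTT assay, with a stated time of 72 h (a lower number here means a stronger inhibitor, a higher number a weaker inhibitor), compound 1 `CCCCCn1ccnc1-c1cc(OC)c(OC)c(OC)c1`, which carries a pentyl chain there, gives 34200 nM. Compound 2 `COc1cc(-c2nccn2S(=O)(=O)c2ccccc2)cc(OC)c1OC` reads > 100000 nM, which is a limit of the assay and not a number. Compound 3 `COc1cc(-c2nccn2-c2cccc([N+](=O)[O-])c2)cc(OC)c1OC` reads > 100000 nM, again a limit. For the measured compounds named here, compound 1 therefore holds the only true number so far. The other two stand at the limit of > 100000 nM in this assay, at which 2 of the 3 values shown sit.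

Compound 4 `COc1ccc(-n2ccnc2-c2cc(OC)c(OC)c(OC)c2)cc1` has not yet been measured. It keeps the core of compound 1 and changes one group: 4-methoxyphenyl in place of pentyl on an aromatic nitrogen, with 4-methoxyphenyl in place of pentyl on an aromatic nitrogen.

No measured step links any two of these compounds, so the expectation rests on little. Compound 3 also has a six-membered aromatic ring on that nitrogen, and it reads > 100000 nM, a limit, so such a ring gives no assurance of activity. Any gain is expected to be modest, and a loss remains possible. The step expected in this assay is a 3.4-fold lower number from compound 1 to compound 4 (0.53 log units; beyond the scatter), toward a stronger inhibitor, and it is only a loose estimate. For compound 4 the estimated value is 10000 nM, with an expected range from 300 nM to 100000 nM.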

Compound 4, half-maximal inhibitory concentration: 2700 nM
Compound 4: middle estimate off by 3.7-fold (0.57 log units), on the high side; low and high end bracket the measured number.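

In this assay, 4-methoxyphenyl in place of pentyl gives a 13-fold lower number from compound 1 to compound 4 (1.10 log units; beyond the scatter), so the group on this aromatic nitrogen can change the read-out by a large step, and for this pair the ring-bearing group is the stronger one. Before this result, the only six-membered aromatic ring seen on this nitrogen was in compound 3, and compound 3 reads > 100000 nM, which is a limit of the assay and not a number. Compound 4 now shows that such a ring can sit here and still give a true number, so the ring alone does not settle the outcome, and compound 3 stands as the case against any simple rule that a ring helps.

The compounds shown leave open whether the gain belongs to the ring or to its methoxy group, a question that a plain phenyl on the same nitrogen would address, and whether a longer chain or a chain ending in an amine could match 4-methoxyphenyl. Little can be ranked beyond this one pair: the limit of > 100000 nM in this assay, at which 2 of the 4 values shown sit.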